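A few compounds are considered here, and "the series" means these few. Any claim that something is new, unique, unknown or untested is made for them only; others in the source may bear on it.

Measured so far:
- compound 1, `O=S1(=O)CCC(NCCCCN(C[C@H]2Cc3ccccc3CN2)[C@H]2CCCc3cccnc32)CC1`: in a functional assay on cells for agonist activity at C-X-C chemokine receptor type 4 (Homo sapiens), read by fluorescence and calcium flux, with a stated time of 90 s (a lower number here means that less compound is needed, a higher number that more compound is needed for the effect), compound 1 gives > 30000 nM, which is a limit of the assay rather than a number.
- compound 2, `NCc1cccc(CN(C[C@H]2Cc3ccccc3CN2)[C@H]2CCCc3cccnc32)c1`: in this assay compound 2 gives > 30000 nM, again a limit and not a number.

Among the measured compounds shown here, compound 2 therefore stands at the limit of > 30000 nM in this assay, at which 2 of the 2 values shown sit, and no numbered potency is available for it; the other measured compound sits at the same limit, so there is no step between measured compounds to lean on.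

Compound 3, `CC(C)(N)CCCN(C[C@H]1Cc2ccccc2CN1)[C@H]1CCCc2cccnc21`, is the next compound to be tested in this assay. Its change from compound 2 is 3-amino-3-methylbutyl in place of 3-(aminomethyl)phenyl on a saturated chain carbon bound to an amine nitrogen: the flat aromatic ring carrying the amine is replaced by a short branched chain ending in an amine, while the shared core is untouched.

For the measured compounds named here, with both measured compounds at the limit, there is no measured step to guide the direction or size of the step expected in this assay. The expectation for compound 3 is that it remains at the limit, with no change beyond the scatter, meaning a step of a number no higher from compound 2 to compound 3 (the limit leaves the size open). The estimate for compound 3 in this assay is 30000 nM, within 10000 nM to 100000 nM.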

Compound 3, half-maximal effective concentration: > 30000 nM
Compound 3: no number, only a limit; the forecaster's own chance of this, stated with the estimate: 85%; the middle value sits exactly at the limit.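

In this assay compound 3 gives > 30000 nM, which is a limit and not a number. Its steps from compound 1 and compound 2 therefore cannot be read, because all three compounds sit at the same point: the limit of > 30000 nM in this assay, at which 3 of the 3 values shown sit.

The compounds shown leave open how far any of these changes moves the potency, and what structure would give a numbered value.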